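The source may hold more compounds than are shown below. What is called first, only, known or untested is meant among the compounds shown, and "the series" means these compounds.

Values so far in a physicochemical assay for solubility, read by HPLC, using the shake flask method, measured as kinetic solubility, with a stated time of 20 h, at pH 6.5, tested at 200 uM; on this read-out lower numbers stand for lower solubility and higher numbers for higher solubility:
- compound 1 `CS(=O)(=O)c1cccc(-c2ccc3nccc(N4CCNCC4)c3n2)c1` gives 165000 nM
- compound 2 `O=S(=O)(c1cccc(Nc2ccc3nccc(-c4ccncc4)c3n2)c1)N1CCCCC1` gives 15000 nM
- compound 3 `NS(=O)(=O)c1cncc(-c2ccc3nccc(-c4cn[nH]c4)c3n2)c1` gives < 5000 nM (a limit of the assay, not a number)

Of the two true numbers, compound 2 holds the lower one at 15000 nM, and compound 1 stands higher by a gap beyond the usual scatter. Compound 3 sits only at a limit, < 5000 nM.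

The next compound to be read is compound 4 `O=S(=O)(NCCO)c1cccc(Nc2ccc3nccc(-c4ccncc4)c3n2)c1`. Its difference from compound 2 is (2-hydroxyethyl)amino in place of piperidin-1-yl on a sulfonyl sulfur. In words, (2-hydroxyethyl)amino stands in place of piperidin-1-yl on a sulfonyl sulfur.

Within the data shown here, no pair of measured compounds differs in one place, so no measured step calibrates this change. A moderate upward step is expected in this assay, starting from compound 2 at 15000 nM, though with wide uncertainty. The expected step is a 2.0-fold higher number from compound 2 to compound 4 (0.30 log units; within the scatter). The estimate for compound 4 is 30000 nM, with an expected range of 8000 nM to 110000 nM.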

Compound 4, solubility: 115000 nM
The estimate for compound 4 lay 3.8-fold (0.58 log units) below the measured number; the whole stated range lies below it.
By their numbers in this assay, from the lowest: compound 2; then compounds 4 and 1 (each within the scatter of the next). At a limit, below all of these: compound 3.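

In this assay, among these compounds, the first one-place comparison falls on the sulfonyl sulfur, where (2-hydroxyethyl)amino in place of piperidin-1-yl gives a 7.7-fold higher number from compound 2 to compound 4 (0.88 log units; beyond the scatter). Among the compounds shown here, the earlier compounds differ in several places at once, so this is the first sign that the group on the sulfonyl sulfur alone can move the read-out beyond the scatter while the rest of the structure stays fixed. Neither end of the step is a limit, so its size can be read as it stands: the limit of < 5000 nM in this assay, at which 1 of the 4 values shown sits.

Going by these compounds, it remains open whether the step follows the loss of the piperidine ring or the arrival of the hydroxyl, which morpholin-4-yl, ethylamino or (2-methoxyethyl)amino on the same sulfur would help to separate. Also open, on these data alone, is whether the same change carries over to the sulfonyl group on another core, such as that of compound 1.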